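Trimming the thiophene: from aryl to chloro at the sulfur side

The compounds below may be only part of what the source reports. "The series", "measured", "known", "first", "only" and "open" are said of these compounds alone.

Measured compounds:
- Compound 1, `CC(=O)c1ccc(-c2sc(N)c(C(=O)c3ccccc3)c2-c2cccc(C(F)(F)F)c2)cc1`: > 10 uM
- Compound 2, `Nc1sc(-c2ccc(Cl)cc2)c(-c2cccc(C(F)(F)F)c2)c1C(=O)c1ccccc1`: > 10 uM

Both compounds were tested in a functional assay on CHO-K1 cells for agonist activity at adenosine receptor A1 (Homo sapiens), read by GTPgammaS binding; a higher number here means that more compound is needed for the effect, a lower number that less compound is needed. Compound 1 gives > 10 uM there, which is a limit of the assay and not a number. Compound 2 likewise gives > 10 uM, again a limit and not a number. Within the data shown here, the single measured step, a step that the two limits leave unreadable from compound 1 to compound 2, is therefore unreadable, as the limit of > 10 uM in this assay, at which 2 of the 2 values shown sit, records.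

Compound 3, `Nc1sc(Cl)c(-c2cccc(C(F)(F)F)c2)c1C(=O)c1ccccc1`, has not been measured. The change chloro in place of 4-chlorophenyl on an aromatic carbon removes the whole aromatic ring on that carbon and leaves only a chlorine. Among the measured compounds shown here, no measured step bears on this change: the one known step concerns a different position and has no readable size. The two shared values offer no reason to expect a step beyond the scatter in either direction. Compound 3 is therefore expected to sit near the same limit, with an estimate of 20 uM, range 5 uM to 100 uM, a step that the limit leaves unreadable from compound 2 to compound 3.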

Compound 3, concentration for half-maximal effect: > 10 uM
Compound 3: no number, only a limit; the forecaster's own chance of this, stated with the estimate: 85%; the middle value does not contradict the limit.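

In this assay compound 3 gives > 10 uM as a limit of the assay and not a number. Among these compounds, no step among compound 1, compound 2 and compound 3 can be read: the limit of > 10 uM in this assay, at which 3 of the 3 values shown sit.

The compounds shown leave open whether swapping 4-acetylphenyl, 4-chlorophenyl and chloro changes the read-out at all.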